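Removing a Chloro Group From a Dichloro Purine-Like Core

This account rests on a few compounds, and the source may have more. Where it says the series, first, only, none or still open, it means among the compounds named here.

Compound 1 `ClCc1cccc(Cn2cnc3c(Cl)nc(Cl)nc32)c1` — 3380 nM
Compound 2 `ClCc1ccc(Cn2cnc3c(Cl)nc(Cl)nc32)cc1` — 4170 nM
Compound 3 `ClCc1ccc(Cn2cnc3nc(Cl)nc(Cl)c32)cc1` — 3230 nM

Of the compounds shown here, three have been tested in a functional assay on LOX IMVI cells (Homo sapiens) for cytotoxicity, read by sulforhodamine B assay, with a stated time of 48 h; on this read-out lower numbers stand for stronger inhibition of growth and higher numbers for weaker inhibition of growth. All three carry the same chloromethyl-benzyl arm and the same dichloro-substituted core, and they differ only in where the arm is attached. In this assay compound 1 gives 3380 nM, compound 2 gives 4170 nM, and compound 3 gives 3230 nM. Compound 1 has the second highest of the three numbers, but its gap to compound 3 and its gap to compound 2 both lie within the usual scatter of the measurement, so the three cannot be separated from one another.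

Compound 4 `ClCc1cccc(Cn2cnc3c(Cl)ncnc32)c1` has not yet been measured. It is compound 1 with one change: hydrogen in place of chloro on an aromatic carbon. Within the data shown here, no pair among the measured compounds shows this kind of change, so its effect cannot be read from the numbers above. The expectation is a modest move toward weaker growth inhibition, a step of a 1.6-fold higher number from compound 1 to compound 4 (0.21 log units; within the scatter), since compound 1 and compound 4 share everything else. Compound 4 is therefore estimated at 5500 nM in this assay, within a range of 2500 nM to 12000 nM.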

Compound 4, concentration for total growth inhibition: 5010 nM
Beside the measured number, compound 4's estimate is 1.1-fold (0.04 log units) above it; measured number inside the range.
By their numbers in this assay, from the lowest: compounds 3, 1, 2 and 4 (each within the scatter of the next).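

Among these compounds, the earlier compounds varied only in where the arm is attached, so compound 4 gives the first look at the chloro group on the aromatic carbon between two ring nitrogen atoms. Hydrogen in place of chloro there gives a 1.5-fold higher number from compound 1 to compound 4 (0.17 log units; within the scatter) in this assay and that step lies within the usual scatter, so the two compounds cannot be told apart and this chloro group is not shown to be required for the growth inhibition seen here. Nothing available here bears on what lies behind this result.

With a single replacement at this carbon, the compounds shown leave open whether a different group there, such as an amine or a methoxy group, would move the number beyond the scatter. They also leave open whether hydrogen in place of the chloro group that stays on the same ring, or a change to the chloromethyl group on the arm, would matter more, since every compound shown keeps both of those groups.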